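The compounds below may be only part of what the source reports. "The series", "measured", "known", "first", "only" and "open" are said of these compounds alone.

Measured so far:
compound 1, `COc1ccc(-c2cn3ccnc3c(-c3ccc4ncn(C5CCCCC5)c4c3)n2)cc1`, 68.4%
compound 2, `c1ccc2c(-c3cn4ccnc4c(-c4ccc5ncn(C6CCCCC6)c5c4)n3)cccc2c1`, 9.08%

Both numbers come from a functional assay on SNB-19 cells (Homo sapiens) for inhibition, read by sulforhodamine B assay, with a stated time of 48 h, tested at 10 uM; on this read-out higher numbers stand for more inhibition at the one concentration tested (going by the name of the read-out) and lower numbers for less inhibition. Compound 2 stands lowest of the two, with compound 1 the nearest and higher, beyond the scatter. For the measured compounds named here, the only step recorded is a number 59.3 percentage points lower from compound 1 to compound 2 (beyond the scatter), a large fall beyond the scatter.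

Compound 3, `Clc1ccc(-c2cn3ccnc3c(-c3ccc4ncn(C5CCCCC5)c4c3)n2)cc1`, is not yet measured. The change is 4-chlorophenyl in place of naphthalen-1-yl on an aromatic carbon. This reverses the move that produced compound 2: a single six-membered aromatic ring returns at the same place, as in compound 1, though bearing chlorine rather than methoxy. Since the step from compound 1 to compound 2 was large and downward, its undoing is expected to carry the number back up, most of the way toward compound 1, with the substituent swap leaving the size uncertain. Compound 3 is estimated at 50%, range 20% to 80%. The expected step is a number 40.9 percentage points higher from compound 2 to compound 3 (beyond the scatter).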

Compound 3, a percentage reported as inhibition, at one concentration (the size of the read-out at that concentration, not a potency): 15.8%
Estimate against measurement, compound 3: 34.2 percentage points above; the measured number lies below the stated range.
By their numbers in this assay, from the lowest: compounds 2 and 3 (each within the scatter of the next); then compound 1.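

In this assay the step is a number 6.7 percentage points higher from compound 2 to compound 3 (within the scatter) and shows that, at this position, 4-chlorophenyl in place of naphthalen-1-yl does not bring back the high number, so a single aromatic ring of carbon alone is not sufficient. With the ring kept, chloro in place of methoxy gives a number 52.6 percentage points lower from compound 1 to compound 3 (beyond the scatter) and so separates compound 1 from compound 3 on the substituent alone; among these three compounds, only the 4-methoxyphenyl group goes with the high number. Nothing available here bears on why these differences arise.

Open, on these data alone, is whether methoxy itself matters: an ethoxy, a hydroxy or a dimethylamino group on the same phenyl ring would test this. The compounds also leave open how an unsubstituted phenyl ring would read, and what replacing the cyclohexyl group, shared by all three, would do.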